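The source may report more compounds than this note shows. Statements on the series, on what has been measured and on what is new or still open speak of the compounds shown alone.

Three compounds share one core. Compound 1 `COc1ccc(-c2nc3cc(C(F)(F)F)ccc3[nH]2)c(N)c1` gives 50000 nM in an ADME assay on Vero cells (Chlorocebus sabaeus) for cytotoxicity; a higher number here means that more compound is tolerated, a lower number that less compound is tolerated; compound 2 `CC(=O)Nc1ccc(-c2nc3cc(C(F)(F)F)ccc3[nH]2)cc1` gives 50000 nM; compound 3 `O=[N+]([O-])c1ccc(-c2nc3cc(C(F)(F)F)ccc3[nH]2)cc1` gives 45000 nM. Compound 3 sits with compounds 1 and 2 in this assay, all three values within the scatter of one another. Among the measured compounds shown here, the single step between measured compounds, a 1.1-fold lower number from compound 2 to compound 3 (0.05 log units; within the scatter), was flat. Compound 4 `COc1ccc(-c2nc3cc(C(F)(F)F)ccc3[nH]2)cc1` differs from compound 3 by methoxy in place of nitro on an aromatic carbon. For the measured compounds named here, no measured step exchanges nitro for methoxy at this position, so the only guide is that compounds 1, 2 and 3 all sit at one level in this assay. Compound 4 is therefore expected to stay at that level, with a step of a 1.1-fold higher number from compound 3 to compound 4 (0.05 log units; within the scatter) expected, giving an estimate of 50000 nM in this assay, between 30000 nM and 65000 nM.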

Compound 4, half-maximal cytotoxic concentration: 15000 nM
Compound 4: middle estimate off by 3.3-fold (0.52 log units), on the high side; the measured number lies below the stated range.
By their numbers in this assay, from the lowest: compound 4; then compounds 3, 1 and 2 (each within the scatter of the next).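

In this assay, among the compounds shown here, methoxy on an aromatic carbon para to a large group is the first change to go beyond the scatter, replacing nitro (a 3.0-fold lower number from compound 3 to compound 4 (0.48 log units; beyond the scatter)) or acetamido (a 3.3-fold lower number from compound 2 to compound 4 (0.52 log units; beyond the scatter)). Methoxy alone does not set this level: compound 1 also carries methoxy, and hydrogen in place of its amino gives a 3.3-fold lower number from compound 1 to compound 4 (0.52 log units; beyond the scatter). No measurement shown accounts for these steps.

Open, from the compounds shown here alone, is whether a longer chain such as ethoxy, or a carboxylic acid, at this position would stay with compound 4 or with compounds 1, 2 and 3.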